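This account rests on a few compounds, and the source may have more. Where it says the series, first, only, none or still open, it means among the compounds named here.

Two compounds of the series carry numbers in an in vitro functional assay on 1321-N1 cells for agonist activity at Free fatty acid receptor 1 (Homo sapiens), read by fluorescence, spectrophotometry and calcium flux; on this read-out higher numbers stand for an effect only at larger amounts of compound and lower numbers for an effect already at smaller amounts. Compound 1 `Cc1ccccc1-c1cc(C#Cc2ccc(CCC(=O)O)cc2)ccn1` gives 1070 nM. Compound 2 `O=C(O)CCc1ccc(C#Cc2cccs2)cc1` gives 251 nM, the lowest of the two numbers; compound 1 sits a distance away that exceeds the usual scatter. Compound 3 `O=C(O)CCc1ccc(C#Cc2ccccn2)cc1` differs from compound 2 by pyridin-2-yl in place of thiophen-2-yl on a triple-bonded carbon. Going by the values given here, no measured pair shows this change, so its effect in this assay cannot be read from the series. A modest rise is expected, estimated as a 2.0-fold higher number from compound 2 to compound 3 (0.30 log units; within the scatter). For compound 3 the expected value in this assay is 500 nM, within a range from 150 nM to 1700 nM.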

Compound 3, half-maximal effective concentration: 13200 nM
The estimate for compound 3 lay 26-fold (1.42 log units) below the measured number, outside the stated range (above it).
By their numbers in this assay, from the lowest: compound 2; then compound 1; then compound 3.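

In this assay, going by these compounds alone, pyridin-2-yl in place of thiophen-2-yl on a triple-bonded carbon brings a 53-fold higher number from compound 2 to compound 3 (1.72 log units; beyond the scatter) and gives the first single-place step, showing that the number at this position depends strongly on which ring is attached. Both rings count one hetero atom and one hydrogen-bond acceptor, yet the numbers still lie far apart. No available evidence accounts for the step.

Going by these compounds, whether the step follows ring size or the hetero atom stays open. Furan-2-yl and pyridin-3-yl at this place would help separate the two.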